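The compounds below may be only part of what the source reports. "The series", "measured", "known", "first", "only" and "open" are said of these compounds alone.

Working notes on the series. Compound 1 `Cc1ccc(CNC(=O)[C@H](CCc2ccccc2)NC(=O)[C@H](CNC(=O)CC(C)(C)C)NC(=O)CCc2ccccc2)cc1` gives "not determined" (no result reported) in an assay on HEK293 cells for inhibition of nuclear factor NF-kappa-B complex (Homo sapiens), read by a luciferase reporter, with stated times of 1 h and 3 h (on this read-out higher numbers stand for weaker inhibition and lower numbers for stronger inhibition), so no number stands for it. Compound 2 `CC(C)(C)CNC(=O)C[C@H](NC(=O)C(C)(C)C)C(=O)N[C@@H](CCc1ccccc1)C(=O)NCc1ccccc1` gives 62 nM in this assay, and compound 3 `CC(C)(C)CNC(=O)C[C@H](NC(=O)CCc1ccccc1)C(=O)N[C@@H](CCc1ccccc1)C(=O)NCc1ccccc1` gives 12 nM, the lower of the two numbers, the step being a 5.2-fold lower number from compound 2 to compound 3 (0.71 log units; beyond the scatter). Compound 4 `CC(C)(C)CNC(=O)C[C@H](NC(=O)C(=O)c1c[nH]c2ccccc12)C(=O)N[C@@H](CCc1ccccc1)C(=O)NCc1ccccc1` differs from compound 3 by (1H-indol-3-yl)carbonyl in place of phenethyl on a carbonyl carbon. Among the compounds with values here, only the step from compound 2 to compound 3 bears on the same carbonyl carbon; it shows that a change there can move the number by a 5.2-fold lower number from compound 2 to compound 3 (0.71 log units; beyond the scatter), but nothing measured separates an indole-bearing group from phenethyl. Expected for compound 4: a step of a 2.1-fold higher number from compound 3 to compound 4 (0.32 log units; beyond the scatter), not resolved beyond the scatter. Compound 4 is therefore estimated at 25 nM in this assay, within 6 nM to 120 nM.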

Compound 4, half-maximal inhibitory concentration: 25 nM
Estimate against measurement, compound 4: no gap at the digits printed; the measured number falls inside the stated range.
By their numbers in this assay, from the lowest: compound 3; then compound 4; then compound 2.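

At this carbonyl carbon, (1H-indol-3-yl)carbonyl gives a 2.1-fold higher number from compound 3 to compound 4 (0.32 log units; beyond the scatter) and so does not match phenethyl, while it still gives a 2.5-fold lower number from compound 2 to compound 4 (0.39 log units; beyond the scatter) against tert-butyl. Both groups carrying an aromatic ring thus give lower numbers than tert-butyl in this assay, and the position tolerates the entering indole with its hydrogen-bond donor at a modest cost relative to phenethyl. Nothing on hand accounts for this order. The compounds shown leave open whether the indole ring or the added carbonyl carries the step from phenethyl, which a benzoyl group or a 2-(1H-indol-3-yl)ethyl group would separate. They also leave open how a carboxylic acid or an amine on this chain would read.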